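Inverting one oxirane stereocentre: compound 3 to compound 4

This account rests on a few compounds, and the source may have more. Where it says the series, first, only, none or still open, it means among the compounds named here.

In a functional assay on MDCK cells (Canis lupus familiaris) for inhibition (on this read-out higher numbers stand for lower toxicity in this test and lower numbers for higher toxicity in this test), compound 1 `Cn1c(CC2(C)CO2)cc(=O)n(C)c1=O` gives 4000 nM and compound 2 `Cn1c(CC2(c3ccccc3)CO2)cc(=O)n(C)c1=O` gives 3700 nM in the same test. Compound 3 `C[C@H]1O[C@@]1(C)Cc1cc(=O)n(C)c(=O)n1C` gives 89000 nM as the highest number of the three, well clear of both others.

The next structure is compound 4 `C[C@@H]1O[C@@]1(C)Cc1cc(=O)n(C)c(=O)n1C` and the change from the previous one is this: the two compounds have the same atoms and bonds and differ only in configuration as drawn: 1 of 2 stereo elements differ; a stereocentre at a saturated ring carbon is drawn R in compound 3 and S in compound 4 with nothing leaving and nothing entering.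

Among the measured compounds shown here, no measured step inverts a stereocentre, so none gauges this change directly. For the measured compounds named here, two steps bear on it indirectly. Phenyl in place of methyl on a saturated ring carbon gives a 1.1-fold lower number from compound 1 to compound 2 (0.03 log units; within the scatter) and so leaves the number unmoved. The 2,3-dimethyloxiran-2-yl in place of 2-methyloxiran-2-yl gives a 22-fold higher number from compound 1 to compound 3 (1.35 log units; beyond the scatter) as a large step, yet that group has been measured in one configuration only. The data do not show whether the high number follows the group or its configuration.

A partial return towards the lower numbers is the working expectation, so the estimated change is a 2.5-fold lower number from compound 3 to compound 4 (0.41 log units; beyond the scatter) with wide uncertainty. For compound 4 the estimated value is 35000 nM with an expected range from 6000 nM to 120000 nM as the likely span.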

Compound 4, half-maximal cytotoxic concentration: 89000 nM
For compound 4 the middle estimate is 2.5-fold (0.41 log units) below the measured one; low and high end bracket the measured number.
By their numbers in this assay, from the lowest: compounds 2 and 1 (each within the scatter of the next); then compounds 3 and 4 (each within the scatter of the next).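

Inverting the stereocentre at the saturated ring carbon in this assay gives no change at the digits printed from compound 3 to compound 4 (within the scatter), so at this ring carbon the drawn configuration leaves the number unmoved. The other drawn form of the group also gives a 22-fold higher number from compound 1 to compound 4 (1.35 log units; beyond the scatter) with 2,3-dimethyloxiran-2-yl in place of 2-methyloxiran-2-yl, which means that the high number now stands for both of these forms and, within the compounds shown, goes with the group and not with one configuration at this carbon. The pair can be read as a test of configuration alone on one ground: the fact that compounds 3 and 4 differ only in the configuration as drawn

Among the compounds shown here, still open is whether the other stereo element, the one that compound 3 and compound 4 share as drawn, is equally without effect on the number when it is inverted. Also open, as far as these compounds go, is whether the high number holds when an ethyl group, a longer chain or an aminomethyl group takes the place of the added methyl on the oxirane ring.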